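The source may report more compounds than this note shows. Statements on the series, on what has been measured and on what is new or still open speak of the compounds shown alone.

In a functional assay (muscle tissue) with Cavia porcellus as the target (on this read-out lower numbers stand for an effect already at smaller amounts and higher numbers for an effect only at larger amounts of compound), three compounds with a shared core have been measured. Compound 1 `COC(=O)C1=C(C)N=C(C)/C(=C(\O)OC)C1c1cc(Cl)cc(Cl)c1` carries a 3,5-dichlorophenyl group and reads 93.3 nM here. Compound 2 `COC(=O)C1=C(C)N=C(C)/C(=C(\O)OC)C1c1ccccc1Br` carries a 2-bromophenyl group and reads 7.59 nM here. Compound 3 `COC(=O)C1=C(C)N=C(C)/C(=C(\O)OC)C1c1cccc(C)c1` carries a 3-methylphenyl group and reads 110 nM here. This places compound 3 within the scatter of compound 1 and far from compound 2, with a 14-fold higher number from compound 2 to compound 3 (1.16 log units; beyond the scatter) as the measured step.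

The next compound, compound 4 `COC(=O)C1=C(C)N=C(C)/C(=C(\O)OC)C1c1cccc(C#N)c1`, has cyano in place of methyl on an aromatic carbon, meta to a large group, so 3-methylphenyl becomes 3-cyanophenyl cyano in place of methyl on an aromatic carbon in this one change. Going by the values given here, no measured compound carries a cyano group, so no step shows this swap directly. The closest guide is a 1.2-fold higher number from compound 1 to compound 3 (0.07 log units; within the scatter) as a step between the two compounds without the 2-bromophenyl group. The large steps, a 12-fold lower number from compound 1 to compound 2 (1.09 log units; beyond the scatter) and the one already given, both involve that group, which compound 4 lacks. In this assay no step beyond the scatter is therefore expected, and so no clear direction either, though the evidence is thin. The estimated step is a 1.6-fold lower number from compound 3 to compound 4 (0.20 log units; within the scatter) on this reasoning. For compound 4 the expected value is 70 nM with an estimated range from 15 nM to 250 nM overall.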

Compound 4, half-maximal effective concentration: 34.7 nM
Compound 4: the middle estimate sits 2.0-fold (0.30 log units) above what was measured, and the stated range covers the measured number.
By their numbers in this assay, from the lowest: compound 2; then compound 4; then compounds 1 and 3 (each within the scatter of the next).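

In this assay, cyano in place of methyl on this aromatic carbon, meta to a large group, gives a 3.2-fold lower number from compound 3 to compound 4 (0.50 log units; beyond the scatter), so a change at this place can move the number beyond the scatter even without the 2-bromophenyl group. The 3-cyanophenyl group also separates from the 3,5-dichlorophenyl group, with a 2.7-fold lower number from compound 1 to compound 4 (0.43 log units; beyond the scatter), whereas the 3-methylphenyl and 3,5-dichlorophenyl groups had stayed within the scatter of each other, but the 2-bromophenyl group still gives the lowest number of the set, with a 4.6-fold higher number from compound 2 to compound 4 (0.66 log units; beyond the scatter). Nothing available here explains why the swap from methyl to cyano shifts the number in this direction.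

The compounds shown leave open how other groups on this same aromatic carbon, such as an amine, a carboxylic acid or a methoxy group, would compare with methyl and cyano. They also leave open whether the step from methyl to cyano would keep its direction and size on a phenyl ring that also carries a bromine or a chlorine.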